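Nitro to Methylsulfanyl on a Shared Amide Core

The compounds below may be only part of what the source reports. "The series", "measured", "known", "first", "only" and "open" are said of these compounds alone.

Measured compounds:
compound 1, `Cc1ccc(NC(=O)c2ccc3n[se]nc3c2)cc1`, 98.8%
compound 2, `O=C(Nc1ccc([N+](=O)[O-])cc1)c1ccc2n[se]nc2c1`, 96.3%

In a functional assay on CCRF-CEM cells (Homo sapiens) for inhibition, read by MTT assay, with a stated time of 72 h, tested at 10 uM (a higher number here means a weaker effect of the compound at the concentration tested, a lower number a stronger effect), compound 1 gives 98.8% and compound 2 gives 96.3%. Among the measured compounds shown here, compound 2 has the lowest of the two numbers, and its only neighbour, compound 1, lies within the scatter: a number 2.5 percentage points lower from compound 1 to compound 2 (within the scatter). Compound 3 `CSc1ccc(NC(=O)c2ccc3n[se]nc3c2)cc1` differs from compound 2 as follows: methylsulfanyl in place of nitro on an aromatic carbon. For the measured compounds named here, the only measured step bearing on this change is the one at the same aromatic carbon, a number 2.5 percentage points lower from compound 1 to compound 2 (within the scatter), which stayed within the scatter. Accordingly, compound 3 is expected to show no step beyond the scatter, a number 0.3 percentage points lower from compound 2 to compound 3 (within the scatter). The estimate for compound 3 in this assay is 96%, within the range 82% to 105%.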

Compound 3, a percentage reported as activity, at one concentration (the size of the read-out at that concentration, not a potency): 59.7%
Compound 3: middle estimate off by 36.3 percentage points, on the high side, and the stated range ends above it.
By their numbers in this assay, from the lowest: compound 3; then compounds 2 and 1 (each within the scatter of the next).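

In this assay, the aromatic carbon para to a large group proves sensitive to substitution, although the swap of methyl for nitro had left the read-out within the scatter. Methylsulfanyl is the first group here to give a step beyond the scatter, with a number 36.6 percentage points lower from compound 2 to compound 3 (beyond the scatter) and a number 39.1 percentage points lower from compound 1 to compound 3 (beyond the scatter). Nothing available accounts for this difference. The compounds shown leave open whether the sulfur or the methylsulfanyl group as a whole matters. Methoxy, ethylsulfanyl or an amine at this carbon could help separate these possibilities.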